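This account rests on a few compounds, and the source may have more. Where it says the series, first, only, none or still open, it means among the compounds named here.

Of the compounds shown here, three have been measured in a functional assay on HFL1 cells for antagonist activity at sphingosine 1-phosphate receptor 2 (Homo sapiens), read by ELISA, with a stated time of 24 h, in the presence of a further agent that is not named here; on this read-out higher numbers stand for weaker inhibition and lower numbers for stronger inhibition. Compound 1, `CC(C(=O)O)c1nn(Cc2cn3cc(OCC4CC4)c(C(F)(F)F)cc3n2)c2ccccc2c1=O`, gives 56 nM. Compound 2, `CC(C)(C(=O)O)c1nn(Cc2cn3cc(OCC4CC4)c(Cl)cc3n2)c2ccccc2c1=O`, gives 361 nM. Compound 3, `C[C@H](C(=O)O)n1nc(Cn2cc3cc(OCC4CC4)c(Cl)cc3n2)c2ccccc2c1=O`, gives 197 nM. On these numbers compound 2 stands highest; the gap to compound 3 lies within the scatter, while the gap to compound 1 lies beyond it. Compound 1 differs from compound 2 in more than one place, so its two values show only where the two stand.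

The next compound, compound 4, is `C[C@H](C(=O)O)c1nn(Cc2cn3cc(OCC4CC4)c(Cl)cc3n2)c2ccccc2c1=O`. It differs from compound 2 in a single way: 1-carboxyethyl in place of 1-carboxy-1-methylethyl on an aromatic carbon

Within the data shown here, no step between two measured compounds isolates this change. Still, compound 1, which carries 1-carboxyethyl, gives 56 nM, and the reading for compound 2 is 361 nM, so a lower number for compound 4 is expected, with a moderate step of a 3.3-fold lower number from compound 2 to compound 4 (0.52 log units; beyond the scatter). Compound 4 is thus estimated at 110 nM, in a range from 40 nM to 300 nM in this assay.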

Compound 4, half-maximal inhibitory concentration: 19 nM
Compound 4: middle estimate off by 5.8-fold (0.76 log units), on the high side, outside the stated range (below it).
By their numbers in this assay, from the lowest: compound 4; then compound 1; then compounds 3 and 2 (each within the scatter of the next).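

Among these compounds, replacing 1-carboxy-1-methylethyl with 1-carboxyethyl on this aromatic carbon, next to the ring nitrogen, gives a 19-fold lower number from compound 2 to compound 4 (1.28 log units; beyond the scatter) in this assay, so this is the first comparison to show that the reading is highly sensitive to the group at this position. Among the compounds shown here, the change takes the group from 6 heavy atoms to 5 and brings in a defined stereocentre, while the counted hydrogen-bond donors and acceptors stay the same, and the single step cannot separate these two differences. Nothing measured here explains the size of the step.

The compounds shown leave open how the opposite stereoisomer of 1-carboxyethyl would read on this core. They also leave open how a carboxymethyl group, a longer 2-carboxyethyl chain or an amide in place of the carboxylic acid would compare.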